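The source may hold more compounds than are shown below. What is called first, only, known or untested is meant among the compounds shown, and "the series" means these compounds.

Measured compounds:
- compound 1, `CCCC(=O)N1CC2CC(C1)N2`: 850 nM
- compound 2, `O=C(C1CCC1)N1CC2CC(C1)N2`: 11000 nM
- compound 3, `O=C([C@@H]1C[C@@H]1F)N1CC2CC(C1)N2`: 370 nM

All three share one core and differ only in the group on the carbonyl carbon. In an assay on SH-EP1 cells for agonist activity at Neuronal acetylcholine receptor; alpha4/beta2 (Homo sapiens), read by FLIPR and calcium flux (on this read-out lower numbers stand for an effect already at smaller amounts and higher numbers for an effect only at larger amounts of compound), compound 3 gives the lowest number of the three: the step of a 2.3-fold lower number from compound 1 to compound 3 (0.36 log units; beyond the scatter) is modest, and the step of a 30-fold lower number from compound 2 to compound 3 (1.47 log units; beyond the scatter) is large, so compound 3 stands clearly apart from both.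

Compound 4, `O=C([C@@H]1C[C@H]1F)N1CC2CC(C1)N2`, is not yet measured. Its relation to compound 3 is the two compounds have the same atoms and bonds; at least one stereo element is drawn with a configuration in one of them and without one in the other: 1 of 4 stereo elements differ; a stereocentre at a saturated ring carbon is drawn S in compound 3 and R in compound 4. The group itself stays a 2-fluorocyclopropyl; only the drawn configuration at one saturated ring carbon changes.

For the measured compounds named here, none of the measured steps is of this kind. The steps of a 13-fold higher number from compound 1 to compound 2 (1.11 log units; beyond the scatter) and a 2.3-fold lower number from compound 1 to compound 3 (0.36 log units; beyond the scatter) exchange one group for another, and the step of a 30-fold lower number from compound 2 to compound 3 (1.47 log units; beyond the scatter) shows that the choice of small ring on the carbonyl carbon matters a great deal. What a change of configuration within the same ring does is not shown by any pair here, so the direction of the step cannot be read off.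

With nothing to lean on, compound 4 is estimated to sit close to compound 3, at 700 nM, within a wide range from 150 nM to 4000 nM. The step this estimate implies, a 1.9-fold higher number from compound 3 to compound 4 (0.28 log units; within the scatter), is expected to be small, but a larger difference in either direction would not be surprising.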

Compound 4, half-maximal effective concentration: 870 nM
Estimate against measurement, compound 4: 1.2-fold (0.09 log units) below; the measured number falls inside the stated range.
By their numbers in this assay, from the lowest: compound 3; then compounds 1 and 4 (each within the scatter of the next); then compound 2.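

In this assay, a change of configuration at one saturated ring carbon of the 2-fluorocyclopropyl group matters on its own, with no atom exchanged, although the effect is modest: a 2.4-fold higher number from compound 3 to compound 4 (0.37 log units; beyond the scatter). The lead of the 2-fluorocyclopropyl group over propyl therefore holds for only one of the two drawn forms, as the other form shows no difference from propyl beyond the scatter: a 1.0-fold higher number from compound 1 to compound 4 (0.01 log units; within the scatter); the large gap to cyclobutyl, by contrast, survives the change of configuration: a 13-fold lower number from compound 2 to compound 4 (1.10 log units; beyond the scatter). The stereo comparison carries one caution, which limits how firmly it can be read as a clean contrast between two defined forms: the fact that one of compounds 3 and 4 is drawn with a defined configuration and the other without, at the place where they differ.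

Still open is how the other configurations of the 2-fluorocyclopropyl group would behave, including the mirror-image forms of the two shown here. Also open, from the compounds shown here alone, is what a plain cyclopropyl or a 2-methylcyclopropyl group on the carbonyl carbon would give, and so whether this sensitivity to configuration depends on the fluorine at all.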